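This account rests on a few compounds, and the source may have more. Where it says the series, first, only, none or still open, it means among the compounds named here.

In a functional assay on cells for agonist activity at C-X-C chemokine receptor type 4 (Homo sapiens), read by fluorescence and calcium flux, with a stated time of 90 s (a higher number here means that more compound is needed for the effect, a lower number that less compound is needed), the three compounds measured so far share one core, shown in compound 1 `c1ccc2c(c1)CN[C@@H](CN(CCCCN(Cc1ccncc1)Cc1ccncc1)[C@H]1CCCc3cccnc31)C2`, compound 2 `c1ccc2c(c1)CN[C@@H](CN(CCCCNCC1CCCCC1)[C@H]1CCCc3cccnc31)C2` and compound 3 `c1ccc2c(c1)CN[C@@H](CN(CCCCNCC1CCOCC1)[C@H]1CCCc3cccnc31)C2`, and differ only in the group on the distal amine nitrogen. Compound 1 reaches only the limit of the assay, giving > 30000 nM. Compound 2 likewise stops at the limit, giving > 30000 nM. Compound 3 also sits at the limit, giving > 30000 nM. The step from compound 2 to compound 3, oxan-4-yl in place of cyclohexyl on a saturated chain carbon bound to an amine nitrogen, therefore reads a step that the two limits leave unreadable from compound 2 to compound 3, and nothing more can be taken from it because of the limit of > 30000 nM in this assay, at which 3 of the 3 values shown sit.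

Compound 4 `c1ccc2c(c1)CN[C@@H](CN(CCCCNC1CCOCC1)[C@H]1CCCc3cccnc31)C2` is the next member of the series. It differs from compound 2 by oxan-4-yl in place of cyclohexylmethyl on an amine nitrogen. Among the measured compounds shown here, only one measured step touches this change, the one from compound 2 to compound 3, and its size is hidden by the limits. Every value shown so far sits at the limit, so compound 4 is expected to fall in the same region, with the step from compound 2 to compound 4 estimated at a step that the limit leaves unreadable from compound 2 to compound 4. In this assay compound 4 is expected to give about 40000 nM, between 15000 nM and 120000 nM, most likely reported as a limit again.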

Compound 4, half-maximal effective concentration: > 30000 nM
Compound 4: no number, only a limit (the forecaster's own chance of this, stated with the estimate: 85%); the middle value is on the limit's open side.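

Compound 4 also stops at a limit, so neither the step to it from compound 2 nor the step to it from compound 3 can be read: the limit of > 30000 nM in this assay, at which 4 of the 4 values shown sit.

The compounds shown leave open whether any group on the distal amine nitrogen gives a readable value, and how the four compounds compare with one another.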